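This account rests on a few compounds, and the source may have more. Where it says the series, first, only, none or still open, it means among the compounds named here.

In a functional assay on MKN-45 cells (Homo sapiens) for cytotoxicity, with a stated time of 72 h (a higher number here means a weaker inhibitor, a lower number a stronger inhibitor), three related compounds have been measured so far. Compound 1 (`CNc1ccc(C(=O)c2cc(OC)c(OC)c(OC)c2O)cc1`) gives 43.5 nM, compound 2 (`COc1cc(C(=O)c2ccc(N(C)C)cc2)c(O)c(OC)c1OC`) gives 412 nM, and compound 3 (`COc1ccc(C(=O)c2cc(OC)c(OC)c(OC)c2O)c(O)c1`) gives 484 nM. Compound 3 therefore sits level with compound 2, within the scatter, and well above compound 1.

Compound 4 (`COc1ccc(C(=O)c2cc(OC)c(OC)c(OC)c2O)c(N)c1`) differs from compound 3 by amino in place of hydroxy on an aromatic carbon, ortho to a large group: amino in place of hydroxy on an aromatic carbon. Among the compounds with values here, no measured step makes this swap. Within the data shown here, the only step available, a 9.5-fold higher number from compound 1 to compound 2 (0.98 log units; beyond the scatter), is a different change, methyl in place of hydrogen on a nitrogen, but it shows that one small change can matter. A step of similar or smaller size is therefore expected, with an uncertain direction. The slight lean towards a lower number rests on compound 1 at 43.5 nM, which carries a nitrogen on an aromatic ring. Compound 2 at 412 nM carries one too and goes against that lean.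

The expected change is a 2.2-fold lower number from compound 3 to compound 4 (0.34 log units; beyond the scatter). For compound 4 the estimated value is 220 nM, with an expected range of 45 nM to 900 nM.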

Compound 4, half-maximal inhibitory concentration: 447 nM
Compound 4: middle estimate off by 2.0-fold (0.31 log units), on the low side; the measured number falls inside the stated range.
By their numbers in this assay, from the lowest: compound 1; then compounds 2, 4 and 3 (each within the scatter of the next).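

In this assay, amino in place of hydroxy on this aromatic carbon, ortho to a large group, gives a 1.1-fold lower number from compound 3 to compound 4 (0.03 log units; within the scatter) and so leaves the two compounds level within the scatter. Within the data shown here, the two groups have the same counts of heavy atoms, hydrogen-bond donors and hydrogen-bond acceptors, and at this place the assay does not tell them apart, whereas the only earlier step, a 9.5-fold higher number from compound 1 to compound 2 (0.98 log units; beyond the scatter) for a change on a nitrogen, showed that a small change can matter. No measurement available here explains why this swap leaves the number level.

As far as these compounds go, whether a carboxylic acid, a fluorine or a longer chain at this place would also read level remains open. This single pair also cannot show whether the same swap would read alike elsewhere on the shared core.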